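Variation ortho to the methylsulfonyl group

The compounds below may be only part of what the source reports. "The series", "measured", "known", "first", "only" and "open" are said of these compounds alone.

Three measured compounds share one core and differ only in the group ortho to the methylsulfonyl group. Compound 1 `Cc1cc(-c2ccc(Cl)cc2)c(S(C)(=O)=O)cc1C(=O)N=C(N)N` gives 45 nM in a functional assay for inhibition of sodium/hydrogen exchanger (Oryctolagus cuniculus); a lower number here means a stronger inhibitor, a higher number a weaker inhibitor. Compound 2 `Cc1cc(N2CCC(N)CC2)c(S(C)(=O)=O)cc1C(=O)N=C(N)N` gives 9.8 nM in this assay, and the step of a 4.6-fold lower number from compound 1 to compound 2 (0.66 log units; beyond the scatter) is the only one of the three that is both beyond the scatter and clearly downward. Compound 3 `Cc1cc(-n2ccnc2)c(S(C)(=O)=O)cc1C(=O)N=C(N)N` gives 23 nM in this assay and so stands second highest of the three numbers; the step of a 2.0-fold lower number from compound 1 to compound 3 (0.29 log units; within the scatter) lies within the scatter, whereas a 2.3-fold higher number from compound 2 to compound 3 (0.37 log units; beyond the scatter) lies beyond it.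

Compound 4 `Cc1cc(Nc2ncccn2)c(S(C)(=O)=O)cc1C(=O)N=C(N)N` is not yet measured. The change is (pyrimidin-2-yl)amino in place of 1H-imidazol-1-yl on an aromatic carbon. Among the compounds with values here, no measured step covers this exact exchange; the three steps above only show that this position tolerates unlike groups with modest shifts, the lowest number coming with compound 2, whose group likewise carries a hydrogen-bond donor. A modest downward step or none beyond the scatter is therefore expected, and compound 4 is estimated at 15 nM in this assay, with a range from 5 nM to 45 nM. The expected step from compound 3 is a 1.5-fold lower number from compound 3 to compound 4 (0.19 log units; within the scatter).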

Compound 4, half-maximal inhibitory concentration: 8.3 nM
For compound 4 the middle estimate is 1.8-fold (0.26 log units) above the measured one, within the range that was stated.
By their numbers in this assay, from the lowest: compounds 4 and 2 (each within the scatter of the next); then compounds 3 and 1 (each within the scatter of the next).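

In this assay, within the data shown here, the exchange of 1H-imidazol-1-yl for (pyrimidin-2-yl)amino gives a 2.8-fold lower number from compound 3 to compound 4 (0.44 log units; beyond the scatter), which shows that this position separates two groups that each bring a nitrogen-containing aromatic ring, something the earlier compounds did not show. The same group cannot be told apart from 4-aminopiperidin-1-yl, with a 1.2-fold lower number from compound 2 to compound 4 (0.07 log units; within the scatter), and it stands clear of 4-chlorophenyl, with a 5.4-fold lower number from compound 1 to compound 4 (0.73 log units; beyond the scatter), so two unlike groups now share the low end of the series while 1H-imidazol-1-yl and 4-chlorophenyl share the high end. The exchange brings in a hydrogen-bond donor, a six-membered aromatic ring in place of a five-membered one and more heavy atoms all at once, and no available measurement says which of these accounts for the step.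

The compounds shown leave open how a phenylamino group or an N-methyl(pyrimidin-2-yl)amino group would compare at this position, and such groups would part the amine hydrogen from the ring nitrogens. They also leave open whether a plain amino group or a piperazin-1-yl group would join compound 2 and compound 4 at the low end.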